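Ring Nitrogen Enters the Fluorinated Aryl Group

This account rests on a few compounds, and the source may have more. Where it says the series, first, only, none or still open, it means among the compounds named here.

Measured compounds:
compound 1 `Cc1cc(NC(=O)Cn2nnc(-c3cccc(Cl)c3)n2)n(C2CCCCC2)n1` — 89%
compound 2 `Cc1cc(NC(=O)Cn2nnc(-c3ccccc3F)n2)n(C2CCCCC2)n1` — 88%

In an assay on HEK293 cells for activation of Kir3.1/Kir3.2 (Homo sapiens), read by thallium flux (a lower number here means a smaller maximal response, a higher number a larger maximal response), compound 1 gives 89% and compound 2 gives 88%. The two values lie within the scatter of each other, as the step of a number 1 percentage points lower from compound 1 to compound 2 (within the scatter) shows, so compound 2 cannot be placed apart from compound 1 on these numbers.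

Compound 3 `Cc1cc(NC(=O)Cn2nnc(-c3cccc(F)n3)n2)n(C2CCCCC2)n1` has not been measured. The change from compound 2 is 6-fluoropyridin-2-yl in place of 2-fluorophenyl on an aromatic carbon. Within the data shown here, the only measured step that bears on it is the exchange of one fluorinated or chlorinated aryl group for another at the same position, a number 1 percentage points lower from compound 1 to compound 2 (within the scatter), which stayed within the scatter. On that basis the expected step is a number 1 percentage points lower from compound 2 to compound 3 (within the scatter), with no movement beyond the scatter in either direction. Compound 3 is therefore estimated at 87%, within a range of 74% to 97%.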

Compound 3, largest response reached (Emax), in percent of the reference or control that the assay uses: > 83%
Compound 3: only a limit was reported (the forecaster's own chance of this, stated with the estimate: 3%); the middle value does not contradict the limit.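

In this assay compound 3 gives > 83%, which is a limit and not a number, so the steps to compound 3 from compound 1 and compound 2 cannot be read. The compounds shown leave open whether 6-fluoropyridin-2-yl in place of 2-fluorophenyl alters the maximal response at all.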